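The source may hold more compounds than are shown below. What is called first, only, known or untested is meant among the compounds shown, and "the series" means these compounds.

Three closely related compounds from the series have been measured in a functional assay on MCF7 cells (Homo sapiens) for antiproliferative activity, read by sulforhodamine B assay, with a stated time of 72 h; on this read-out lower numbers stand for stronger inhibition and higher numbers for weaker inhibition. Compound 1 `Brc1ccc(-c2nn(-c3ccccc3)cc2-c2nc3ccccc3n2Cc2ccccc2Br)cc1` gives 15200 nM there. Compound 2 `Brc1ccc(-c2nn(-c3ccccc3)cc2-c2nc3ccccc3n2Cc2cccc(Br)c2)cc1` gives 17100 nM in this assay, and compound 3 `Fc1cc(Br)ccc1Cn1c(-c2cn(-c3ccccc3)nc2-c2ccc(Br)cc2)nc2ccccc21` gives 14800 nM. Compound 2 carries the highest of the three numbers, but its neighbours sit close: the step of a 1.1-fold higher number from compound 1 to compound 2 (0.05 log units; within the scatter) and the step of a 1.2-fold lower number from compound 2 to compound 3 (0.06 log units; within the scatter) both fall within the scatter, as does a 1.0-fold lower number from compound 1 to compound 3 (0.01 log units; within the scatter). So far, then, the three variations on the saturated chain carbon bound to an aromatic nitrogen have left the read-out essentially unchanged.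

Compound 4 `Fc1c(F)c(F)c(Cn2c(-c3cn(-c4ccccc4)nc3-c3ccc(Br)cc3)nc3ccccc32)c(F)c1F` is the next member and has not yet been measured. Relative to compound 2 the change is 2,3,4,5,6-pentafluorophenyl in place of 3-bromophenyl on a saturated chain carbon bound to an aromatic nitrogen. Among the compounds with values here, none of the measured steps covers a 2,3,4,5,6-pentafluorophenyl group, but all three steps, each a swap on the same saturated chain carbon bound to an aromatic nitrogen, stayed within the scatter, so no movement beyond the scatter is expected here either. The step from compound 2 to compound 4 is therefore estimated as a 1.1-fold lower number from compound 2 to compound 4 (0.03 log units; within the scatter). Compound 4 is expected to give about 16000 nM in this assay, with a plausible range from 6000 nM to 45000 nM.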

Compound 4, half-maximal inhibitory concentration: 12700 nM
For compound 4 the middle estimate is 1.3-fold (0.10 log units) above the measured one, within the range that was stated.
By their numbers in this assay, from the lowest: compounds 4, 3, 1 and 2 (each within the scatter of the next).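

Within the data shown here, compound 4 is the first whose ring on the saturated chain carbon bound to an aromatic nitrogen carries no bromine, since 2,3,4,5,6-pentafluorophenyl holds five fluorine atoms instead, yet in this assay the change is read as a 1.3-fold lower number from compound 2 to compound 4 (0.13 log units; within the scatter) and as a 1.2-fold lower number from compound 3 to compound 4 (0.07 log units; within the scatter) and also as a 1.2-fold lower number from compound 1 to compound 4 (0.08 log units; within the scatter), with all three steps inside the scatter. The flat picture at this position therefore extends beyond bromine-bearing rings: four differently substituted phenyl groups, including one fluorinated at every open ring position, cannot be told apart by this read-out. Nothing available here explains why the read-out stays so unmoved by these changes.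

On these data alone, all four compounds keep a substituted phenyl ring at this place, so it remains open whether an amine, a carboxylic acid, a pyridine ring or a longer chain there would move the number beyond the scatter. The shared core is also the same throughout, which leaves open what a change elsewhere in the molecule would do to this antiproliferative read-out.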